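Will a New Carbamoyl Chain Stay Well Tolerated?

This account rests on a few compounds, and the source may have more. Where it says the series, first, only, none or still open, it means among the compounds named here.

In an ADME assay on HOS cells (Homo sapiens) for cytotoxicity, read by luminescence and ATP content, with a stated time of 48 h (a higher number here means that more compound is tolerated, a lower number that less compound is tolerated), compound 1 `CN(C)CCCc1cnc2c(c1)c(N)c(C(=O)NCc1ccc(F)cc1F)c(=O)n2O` gives 5000 nM as its reading. Compound 2 `CN(C)C(=O)CCc1cnc2c(c1)c(N)c(C(=O)NCc1ccc(F)cc1F)c(=O)n2O` yields only a limit, > 250000 nM in this case, and not an exact number. The measured change is an at least 50-fold higher number from compound 1 to compound 2 (1.69 log units; beyond the scatter) with dimethylcarbamoyl in place of (dimethylamino)methyl on the chain.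

Compound 3 `Nc1c(C(=O)NCc2ccc(F)cc2F)c(=O)n(O)c2ncc(/C=C/C(=O)NCCO)cc12` comes next, and the change is 2-((2-hydroxyethyl)carbamoyl)ethenyl in place of 2-(dimethylcarbamoyl)ethyl on an aromatic carbon in which 2-((2-hydroxyethyl)carbamoyl)ethenyl stands in place of 2-(dimethylcarbamoyl)ethyl on an aromatic carbon. Compound 3 keeps a carbamoyl group in its chain, as compound 2 does, and has no dimethylamino group. Going by the values given here, the expectation rests on the single large step of an at least 50-fold higher number from compound 1 to compound 2 (1.69 log units; beyond the scatter) in which that group was lost, so no large fall back toward compound 1 is expected. Among the compounds with values here, no measured step covers the ethenyl or hydroxyethyl parts, which leaves room for a modest fall in this assay and no rise that could be read. The expected size is an at least 1.3-fold lower number from compound 2 to compound 3 (0.14 log units; that floor lies within the scatter) on this estimate. For compound 3 the estimated value is 180000 nM with an expected range from 50000 nM to 300000 nM in this assay.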

Compound 3, half-maximal cytotoxic concentration: > 250000 nM
Compound 3: only a limit was reported; the forecaster's own chance of this, stated with the estimate: 45%; middle value at least 1.3-fold (0.14 log units) away from the limit.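

In this assay compound 3 also gives only a limit, > 250000 nM, and not an exact number. Putting 2-((2-hydroxyethyl)carbamoyl)ethenyl in place of 3-(dimethylamino)propyl on this aromatic carbon gives an at least 50-fold higher number from compound 1 to compound 3 (1.69 log units; beyond the scatter), so a second carbamoyl chain without a dimethylamino group, this one with a double bond in the chain and a hydroxyethyl end, also reads far from the value of compound 1. The step between compound 2 and compound 3 cannot be read, and neither compound can be ranked over the other, because both stop at the same limit: the limit of > 250000 nM in this assay, at which 2 of the 3 values shown sit.

Only compound 1 carries a dimethylamino group, so a single reading ties that group to the lower tolerated concentration, and any effect of the ethenyl link or the hydroxyethyl end stays hidden behind the limits. From the compounds shown here alone, whether a chain ending in a primary amine or a carboxylic acid, or a longer chain, on this aromatic carbon would stay at the limit or fall toward compound 1 also remains open.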